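Swapping the aryl ring on a vinyl sulfide chalcone

The compounds below may be only part of what the source reports. "The series", "measured", "known", "first", "only" and "open" are said of these compounds alone.

Of the compounds shown here, three sharing a common core have been tested in a functional assay on DU-145 cells (Homo sapiens) for inhibition, read by trypan blue exclusion, with a stated time of 96 h; on this read-out lower numbers stand for stronger inhibition of growth and higher numbers for weaker inhibition of growth. Compound 1, `Cc1ccc(CS/C(=C/c2ccc(F)c(C)c2)C(=O)c2ccc(Cl)cc2)cc1`, gives 25000 nM in this assay. Compound 2, `O=C(/C(=C/c1ccc(Br)cc1)S(=O)(=O)Cc1ccc(I)cc1)c1ccc(I)cc1`, gives 20000 nM, and compound 3, `O=C(/C(=C\c1c(O)cc(O)cc1O)SCc1ccc(Cl)c(Cl)c1)c1ccc(Cl)cc1`, gives 25000 nM. The numbers for compound 1 and compound 3 agree at the digits shown, and the number for compound 2 lies within the usual scatter of these two, so none of the three separates from the others. All three sit at the weak end of what this assay resolves.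

Compound 4, `Cc1ccc(CS/C(=C/c2cc([N+](=O)[O-])ccc2F)C(=O)c2ccc(Cl)cc2)cc1`, has not yet been measured. It is built from compound 1 by a single change: 2-fluoro-5-nitrophenyl in place of 4-fluoro-3-methylphenyl on a double-bonded chain carbon bound to a double-bonded chain carbon.

Within the data shown here, no comparable step between measured compounds exists here, so there is no precedent to draw on. Given that compound 1, compound 2 and compound 3 all give numbers within the scatter of one another despite different substituents, no step beyond the scatter is expected for this change. Compound 4 is therefore estimated at 25000 nM, with a plausible range from 10000 nM to 60000 nM, which means an expected step of no change at the digits printed from compound 1 to compound 4 (within the scatter).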

Compound 4, concentration for 50% growth inhibition: 1000 nM
Compound 4: the middle estimate sits 25-fold (1.40 log units) above what was measured, outside the stated range (below it).
By their numbers in this assay, from the lowest: compound 4; then compounds 2, 1 and 3 (each within the scatter of the next).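

In this assay, putting 2-fluoro-5-nitrophenyl in place of 4-fluoro-3-methylphenyl on a double-bonded chain carbon bound to a double-bonded chain carbon gives a 25-fold lower number from compound 1 to compound 4 (1.40 log units; beyond the scatter) and thus a large step. This aryl ring is therefore a place where one change can move growth inhibition strongly, which the three earlier compounds, all within the scatter of one another, gave no sign of. Nothing measured here explains why this step is so large.

As far as these compounds go, it remains open whether the nitro group alone would give the same step, or whether it depends on the fluorine in the same ring. An amine or a carboxylic acid in place of the nitro group would help to show how specific this change is.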